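The source may hold more compounds than are shown below. What is called first, only, known or untested is meant among the compounds shown, and "the series" means these compounds.

Compound 2 `CCCC[C@@H](/C=C\[C@@H]1OC(=O)C=C[C@@H]1O)OC(C)=O` holds the lowest number of the three in a functional assay on MCF7 cells (Homo sapiens) for cytotoxicity, read by sulforhodamine B assay, with a stated time of 48 h (on this read-out higher numbers stand for weaker inhibition and lower numbers for stronger inhibition), giving 1000 nM. Compound 1 `CCCC[C@@H](/C=C\[C@@H]1OC(=O)C=C[C@@H]1OC(C)=O)OC(C)=O` gives 3200 nM in this assay, and compound 3 `CCCC[C@H](O)/C=C\[C@@H]1OC(=O)C=C[C@@H]1O` gives 5900 nM. The two measured steps, a 3.2-fold lower number from compound 1 to compound 2 (0.51 log units; beyond the scatter) and a 5.9-fold higher number from compound 2 to compound 3 (0.77 log units; beyond the scatter), each exchange hydrogen for acetyl on an oxygen on a saturated carbon. Compound 4 `CCCC[C@H](/C=C\[C@@H]1OC(=O)C=C[C@@H]1O)OC(C)=O` differs from compound 2 in another way: the two compounds have the same atoms and bonds and differ only in configuration as drawn: 1 of 4 stereo elements differ; a stereocentre at a saturated chain carbon is drawn S in compound 2 and R in compound 4. Neither measured step touches a configuration, so nothing among the three compounds shows how this inversion will register in this assay; no step beyond the scatter is foreseen, and its direction is open. Compound 4 is therefore estimated at 1500 nM in this assay, within 400 nM to 6000 nM, the expected step being a 1.5-fold higher number from compound 2 to compound 4 (0.18 log units; within the scatter).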

Compound 4, half-maximal inhibitory concentration: 1300 nM
Compound 4: the middle estimate sits 1.2-fold (0.06 log units) above what was measured; the measured number falls inside the stated range.
By their numbers in this assay, from the lowest: compounds 2 and 4 (each within the scatter of the next); then compounds 1 and 3 (each within the scatter of the next).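

In this assay, for the compounds shown here, the earlier steps each changed an acetyl on an oxygen, whereas this is the first to change a configuration, and a 1.3-fold higher number from compound 2 to compound 4 (0.11 log units; within the scatter) leaves the pair within the scatter of each other. The comparison isolates the stereocentre at a saturated chain carbon, and its inversion does not register here, because nothing else separates the pair: the fact that compounds 2 and 4 differ only in the configuration as drawn. Still open, as far as these compounds go, is whether an amine or a longer chain at this carbon would hold the number near that of compound 2, and whether inversion would stay as quiet in compound 1 or compound 3.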